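Swapping cyanomethyl for 2-bromobenzyl: a cytotoxicity outlook

The compounds below may be only part of what the source reports. "The series", "measured", "known", "first", "only" and "open" are said of these compounds alone.

Among the compounds with values here, compound 1 `N#CCN1C(=O)N(Cc2cccc(F)c2)S(=O)(=O)n2cccc21` is the one member of this small set with a numerical read-out: in an ADME assay on MT4 cells (Homo sapiens) for cytotoxicity, read by MTT assay, with a stated time of 5 days (a lower number here means that less compound is tolerated, a higher number that more compound is tolerated), compound 1 gives 172000 nM. Compound 2 `O=C1N(Cc2ccccc2Cl)c2cccn2S(=O)(=O)N1Cc1cccc(Br)c1` reaches only a limit of this assay, > 260000 nM. Compound 3 `N#Cc1ccccc1CN1C(=O)N(Cc2ccccc2)S(=O)(=O)n2cccc21` likewise sits at a limit, > 318000 nM. Compound 1 is therefore the only fixed point, and the other two show merely that they were tolerated up to the top of their tested ranges.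

Compound 4 `O=C1N(Cc2ccccc2Br)c2cccn2S(=O)(=O)N1Cc1cccc(F)c1` differs from compound 1 in one place: 2-bromophenyl in place of cyano on a saturated chain carbon bound to an amide-type nitrogen in a ring. Within the data shown here, no measured pair isolates this change, so its size has to be guessed. Compound 2, which also carries a halogenated benzyl on that nitrogen, stands at the limit of > 260000 nM in this assay, at which 1 of the 3 values shown sits. Compound 3, the other benzyl-bearing analogue, stands at the limit of > 318000 nM in this assay, at which 1 of the 3 values shown sits. On that basis the step from compound 1 to compound 4 is expected to run towards greater tolerance, probably by more than the usual scatter, and it is expected to measure a 1.5-fold higher number from compound 1 to compound 4 (0.18 log units; within the scatter). For compound 4 in this assay the estimated value is 260000 nM, within a range from 130000 nM to 520000 nM, with a fair chance that only a limit is reported.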

Compound 4, half-maximal cytotoxic concentration: > 269000 nM
Compound 4 gave a limit, no number; the forecaster's own chance of this, stated with the estimate: 60%; middle value at least 1.0-fold (0.01 log units) from the limit.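

Within the data shown here, this pair gives the first direct reading at this position: in this assay, 2-bromophenyl in place of cyano on a saturated chain carbon bound to an amide-type nitrogen in a ring gives an at least 1.5-fold higher number from compound 1 to compound 4 (0.19 log units; that floor lies within the scatter). Compound 4 reads as a limit and not as a number: the limit of > 269000 nM in this assay, at which 1 of the 4 values shown sits. Going by these compounds, the step is therefore only a floor, and since that floor lies within the scatter, the pair shows that this large aromatic replacement for the small nitrile brings no loss of tolerance in this assay, but it does not establish a real gain, and the full size of the step remains unknown.

The compounds shown leave open how much of the change belongs to the aromatic ring and how much to the bromine, a question that a plain benzyl or a 2-fluorobenzyl at this place in the frame of compound 1 would address. They also leave open how this position would read with a carboxylic acid or an amine in place of cyano, or with a longer chain.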